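A few compounds are considered here, and "the series" means these few. Any claim that something is new, unique, unknown or untested is made for them only; others in the source may bear on it.

Measured compounds:
- compound 1 `Cc1cc(Nc2ccc(C(=O)/C=C/c3cccc(Br)n3)cc2)n2nc(SCc3ccccc3)nc2n1` gives 90.2% in a functional assay on MGC-803 cells (Homo sapiens) for inhibition, read by sulforhodamine B assay, with a stated time of 72 h, tested at 10 uM; on this read-out higher numbers stand for more inhibition at the one concentration tested (going by the name of the read-out) and lower numbers for less inhibition
- compound 2 `O=C(/C=C/c1cccc(Br)n1)c1ccc(Nc2cc(-c3ccccc3)nc3nc(SCc4ccccc4)nn23)cc1` gives 38.3% in this assay

Compound 1 stands highest of the two numbers. Its nearest neighbour is compound 2, with a number 51.9 percentage points lower from compound 1 to compound 2 (beyond the scatter) — phenyl in place of methyl on an aromatic carbon of the shared core. Among the compounds with values here, that is the only measured step, and it lies at a different part of the molecule from the change now at hand.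

Compound 3 `Cc1cc(Nc2ccc(C(=O)/C=C/c3cccc(Br)n3)cc2)n2nc(SCc3ccc(F)cc3)nc2n1` differs from compound 1 by fluoro in place of hydrogen on an aromatic carbon. Within the data shown here, no measured pair touches the benzylsulfanyl group, so the step from compound 1 to compound 2, large as it is, does not bear directly on this change; it only shows that the core substituent matters strongly, which says nothing about a fluorine on the benzyl ring. With nothing in the data pointing either way and the change amounting to a single fluorine for a hydrogen, a step within the scatter is expected, a number 5.2 percentage points lower from compound 1 to compound 3 (within the scatter). For compound 3 the estimate in this assay is therefore 85%, in the range 68% to 96%.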

Compound 3, a percentage reported as inhibition, at one concentration (the size of the read-out at that concentration, not a potency): 93.3%
Beside the measured number, compound 3's estimate is 8.3 percentage points below it; the measured number falls inside the stated range.
By their numbers in this assay, from the lowest: compound 2; then compounds 1 and 3 (each within the scatter of the next).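

Fluoro in place of hydrogen on the phenyl ring of the benzylsulfanyl group gives the first measured reading at this part of the molecule: in this assay, the exchange gives a number 3.1 percentage points higher from compound 1 to compound 3 (within the scatter). The 4-fluorobenzyl and benzyl compounds therefore cannot be told apart at the one concentration tested, so this position accepts a fluoro group without loss of the read-out, unlike the core exchange that gives a number 51.9 percentage points lower from compound 1 to compound 2 (beyond the scatter). No measurement offered here accounts for this outcome, nor for the size of the core step.

Going by these compounds, compounds 1 and 3 both read high at a single concentration, so any difference in potency between them stays open, as does whether the fluoro exchange would read the same on the phenyl-bearing core of compound 2. A single small atom also says little about how much this ring will accept, and a methoxy group, an amine or a carboxylic acid in the same place, or a longer chain in place of the benzyl group, would test that limit.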